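Benzylamide series: para substituent swap, cyano to methyl

A few compounds are considered here, and "the series" means these few. Any claim that something is new, unique, unknown or untested is made for them only; others in the source may bear on it.

Measured compounds in a functional assay on NCI-H3122 cells (Homo sapiens) for antiproliferative activity, read by MTT assay, with a stated time of 48 h; a higher number here means a weaker inhibitor, a lower number a stronger inhibitor:
compound 1 `COc1cc(CNC(=O)c2cccc(C(C)Oc3ccnc(Nc4cnn(C)c4)c3)c2)cc(OC)c1OC` gives 29000 nM
compound 2 `CC(Oc1ccnc(Nc2cnn(C)c2)c1)c1cccc(C(=O)NCc2ccc(C#N)cc2)c1` gives 35100 nM

Both compounds share one core and differ only in the aryl group on the saturated chain carbon bound to the amide-type nitrogen. Among the compounds with values here, the only measured step, a 1.2-fold higher number from compound 1 to compound 2 (0.08 log units; within the scatter), shows that exchanging 3,4,5-trimethoxyphenyl for 4-cyanophenyl leaves this assay essentially unchanged; compound 2 therefore stands within the scatter of compound 1, and neither can be called the weaker or stronger of the two.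

Compound 3 `Cc1ccc(CNC(=O)c2cccc(C(C)Oc3ccnc(Nc4cnn(C)c4)c3)c2)cc1` carries the change (methyl in place of cyano on an aromatic carbon). This touches the same aryl group whose variation in a 1.2-fold higher number from compound 1 to compound 2 (0.08 log units; within the scatter) made no difference beyond the scatter, so for compound 3 the step of a 1.1-fold lower number from compound 2 to compound 3 (0.04 log units; within the scatter) is expected to stay within the scatter as well, with no clear direction. On that basis compound 3 is estimated at 32000 nM, in a range from 12000 nM to 85000 nM.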

Compound 3, half-maximal inhibitory concentration: 7700 nM
For compound 3 the middle estimate is 4.2-fold (0.62 log units) above the measured one, and the stated range ends above it.
By their numbers in this assay, from the lowest: compound 3; then compounds 1 and 2 (each within the scatter of the next).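

In this assay, the aryl group on the saturated chain carbon bound to the amide-type nitrogen is shown to matter after all: replacing cyano with methyl, para to a large group, gives a 4.6-fold lower number from compound 2 to compound 3 (0.66 log units; beyond the scatter). The 4-methylphenyl group also separates from 3,4,5-trimethoxyphenyl, with a 3.8-fold lower number from compound 1 to compound 3 (0.58 log units; beyond the scatter), whereas 4-cyanophenyl and 3,4,5-trimethoxyphenyl remained within the scatter of each other, so this position responds to some changes and not to others. Nothing available here accounts for the difference between methyl and cyano at this position.

On these data alone, whether the lower number in compound 3 reflects the presence of methyl or the loss of cyano remains open, and the unsubstituted phenyl group would separate these two readings. As far as these compounds go, how an ethyl group, a chlorine atom or an amine in the same place would compare also remains open.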